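The source may report more compounds than this note shows. Statements on the series, on what has been measured and on what is new or still open speak of the compounds shown alone.

Working notes on a four-compound series built on one shared core.

Compound 1 is `Fc1ccc(-c2ccc(-c3ccc(-c4nc5ccccc5[nH]4)cc3)cc2)cc1`, compound 2 is `FC(F)(F)c1ccc(-c2ccc(-c3ccc(-c4nc5ccccc5[nH]4)cc3)cc2)cc1` and compound 3 is `Cc1ccc2[nH]c(-c3ccc(-c4ccc(-c5ccc(F)cc5)cc4)cc3)nc2c1`; compound 4, `Cc1ccc2[nH]c(-c3ccc(-c4ccc(-c5ccc(C(F)(F)F)cc5)cc4)cc3)nc2c1`, remains unmeasured. In a functional assay on A549 cells (Homo sapiens) for inhibition, read by sulforhodamine B assay (a lower number here means a stronger inhibitor of growth, a higher number a weaker inhibitor of growth), compound 1 gives 33200 nM. In this assay compound 2 gives 36600 nM. In this assay compound 3 gives 6030 nM, the lowest of the three numbers, with both steps to it beyond the scatter.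

The change from compound 1 to compound 2 is trifluoromethyl in place of fluoro on an aromatic carbon, and it gave a 1.1-fold higher number from compound 1 to compound 2 (0.04 log units; within the scatter). The core of compound 3 differs from that of compound 1 by methyl in place of hydrogen on an aromatic carbon, which gave a 5.5-fold lower number from compound 1 to compound 3 (0.74 log units; beyond the scatter). Compound 4 carries the same change relative to compound 3, (trifluoromethyl in place of fluoro on an aromatic carbon), on a place described in the same words as before, so this is the same change on the methyl-bearing core.

Going by the values given here, the step from compound 3 to compound 4 in this assay is expected to be a 1.1-fold higher number from compound 3 to compound 4 (0.04 log units; within the scatter), resting on the single earlier instance, a 1.1-fold higher number from compound 1 to compound 2 (0.04 log units; within the scatter), which stayed within the scatter. Compound 4 is therefore estimated at 6600 nM, with a range of 3000 nM to 15000 nM.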

Compound 4, concentration for 50% growth inhibition: 3520 nM
For compound 4 the middle estimate is 1.9-fold (0.27 log units) above the measured one, and the stated range covers the measured number.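

In this assay, trifluoromethyl in place of fluoro gives a 1.7-fold lower number from compound 3 to compound 4 (0.23 log units; within the scatter) on the methyl-bearing core, so this change leaves the number within the scatter on both cores: the same change on two cores in this assay, a 1.1-fold higher number (0.04 log units; within the scatter) from compound 1 to compound 2 and a 1.7-fold lower number (0.23 log units; within the scatter) from compound 3 to compound 4, 1.9-fold (0.28 log units) apart, within the scatter of two such steps. Methyl in place of hydrogen gives a 10-fold lower number from compound 2 to compound 4 (1.02 log units; beyond the scatter) in the trifluoromethyl pair, and it also carries across, with a step beyond the scatter in both pairs: the same change on two cores in this assay, a 5.5-fold lower number (0.74 log units; beyond the scatter) from compound 1 to compound 3 and a 10-fold lower number (1.02 log units; beyond the scatter) from compound 2 to compound 4, 1.9-fold (0.28 log units) apart, within the scatter of two such steps. This shows that the two changes combine without a detectable interaction in these four compounds, but it rests on one pair of cores and one cell line, and it does not show that the steps are identical or that they would hold on any other core.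

The compounds shown leave open whether the methyl step persists with a longer chain such as ethyl in its place. They also leave open whether an amine or a carboxylic acid in place of the fluoro would stay as close to compound 3 as trifluoromethyl does.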